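Three Measured Quinolinone Analogues and an Unmeasured Ester

This account rests on a few compounds, and the source may have more. Where it says the series, first, only, none or still open, it means among the compounds named here.

Measured compounds:
compound 1 `COc1cc2c(=O)c(C(=O)c3ccc(C)cc3)cn(Cc3ccc(N)cc3)c2cc1OC` — "not active" (no number reported)
compound 2 `COc1cc2c(=O)c(C(=O)c3ccc(C)cc3)cn(Cc3ccc(C(F)(F)F)cc3F)c2cc1OC` — > 25000 nM
compound 3 `COc1cc2c(=O)c(C(=O)c3ccc(C)cc3)cn(Cc3ccccc3)c2cc1OC` — "not active" (no number reported)

In an ADME assay on Huh-7 cells (Homo sapiens) for cytotoxicity (on this read-out lower numbers stand for stronger inhibition of growth and higher numbers for weaker inhibition of growth), compound 1 is reported as "not active" (no number reported). Compound 3, which shares the same core, is likewise reported in this assay as "not active" (no number reported). For compound 2 this assay gives only a limit, > 25000 nM, and not a number; this is the assay's own boundary, (the limit of > 25000 nM in this assay, at which 1 of the 3 values shown sits). Compound 2 therefore stands at the edge of what this assay can report, with the two other entries giving no number at all, so no ordering among the three can be drawn.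

Compound 4 `COc1cc2c(=O)c(C(=O)OCc3ccccc3C)cn(Cc3ccc(C(F)(F)F)cc3F)c2cc1OC` has not been measured. It differs from compound 2 by (2-methylbenzyl)oxy in place of 4-methylphenyl on a carbonyl carbon, so that a (2-methylbenzyl)oxy sits in place of 4-methylphenyl on a carbonyl carbon. Going by the values given here, no step between measured compounds is given, so the size of this change cannot be read from the data. Given that compound 2 sits at the limit > 25000 nM, compound 4 is expected to show no step beyond the scatter, a step that the limit leaves unreadable from compound 2 to compound 4. The estimate for compound 4 in this assay is 30000 nM, with a range from 12000 nM to 80000 nM, most likely again reported only as a limit.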

Compound 4, concentration for 50% growth inhibition: 31000 nM
Compound 4: the middle estimate sits 1.0-fold (0.01 log units) below what was measured, and the stated range covers the measured number.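

No step can be read from compound 2 to compound 4 in this assay, because compound 2 is reported only as a limit: the limit of > 25000 nM in this assay, at which 1 of the 4 values shown sits.

The compounds shown leave open how far (2-methylbenzyl)oxy in place of 4-methylphenyl on a carbonyl carbon shifts growth inhibition, and where compound 1 and compound 3 stand relative to compound 4.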